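Swapping the Amide Substituent While Keeping the Alcohol Side Chain

The compounds below may be only part of what the source reports. "The series", "measured", "known", "first", "only" and "open" are said of these compounds alone.

Two measured compounds share one core and differ in two places. Compound 1 `CCn1c(C(=O)NCCN(C)C)ccc1C(CC)(CC)c1ccc(OCC(=O)C(C)(C)C)c(C)c1` gives 1600 nM in a functional assay on Caco-2 cells (Homo sapiens), read by MTT assay, with a stated time of 48 h; a higher number here means a weaker inhibitor, a lower number a stronger inhibitor. Compound 2 `CCn1c(C(=O)NCC(OC)OC)ccc1C(CC)(CC)c1ccc(OCC(O)C(C)(C)C)c(C)c1` stands at the limit of > 50000 nM in this assay, at which 1 of the 2 values shown sits. For compound 2 the assay therefore reports only a limit, > 50000 nM, and not a number. Compound 3 `CCn1c(C(=O)N(C)CC(=O)O)ccc1C(CC)(CC)c1ccc(OCC(O)C(C)(C)C)c(C)c1` has not been measured. It differs from compound 2 in a single place: (carboxymethyl)(methyl)amino in place of (2,2-dimethoxyethyl)amino on a carbonyl carbon. For the measured compounds named here, no measured pair shows what this particular swap does, so the size of the step cannot be read from the data. Starting from a limit, the expected step of an at least 1.2-fold lower number from compound 2 to compound 3 (0.09 log units; that floor lies within the scatter) is none beyond the scatter, in no clear direction. The estimated value for compound 3 is 40000 nM, within a range from 8000 nM to 200000 nM, and it is quite possible that the assay again reports only a limit.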

Compound 3, half-maximal inhibitory concentration: 31900 nM
For compound 3 the middle estimate is 1.3-fold (0.10 log units) above the measured one, within the range that was stated.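

With (carboxymethyl)(methyl)amino on the carbonyl carbon, compound 3 gives a real number in this assay, 31900 nM, so this position can carry a group that brings the reading inside the measured range while the alcohol side chain stays in place. The change from (2,2-dimethoxyethyl)amino amounts to an at least 1.5-fold lower number from compound 2 to compound 3 (0.19 log units; that floor lies within the scatter). That step is known only as a floor because compound 2 stands at a limit of the assay and not at a number: the limit of > 50000 nM in this assay, at which 1 of the 3 values shown sits.

Going by these compounds, the true distance between the two compounds therefore stays open, and so does the question of whether the carboxylic acid or the methyl on the amide nitrogen matters more. A (carboxymethyl)amino group without that methyl, or a longer chain ending in a carboxylic acid, would help separate the two.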